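The source may report more compounds than this note shows. Statements on the series, on what has been measured and on what is new or still open speak of the compounds shown alone.

Of the compounds shown here, three of a shared core have been measured in an assay on SH-EP1 cells for displacement of a labelled ligand from Neuronal acetylcholine receptor; alpha4/beta2 (Homo sapiens), read by scintillation counting; a higher number here means a weaker inhibitor, a lower number a stronger inhibitor. Compound 1 `CCCC(=O)N1CC2CC(C1)N2` gives 14 nM, and compound 2 `O=C(C1CCC1)N1CC2CC(C1)N2` gives 16 nM; the step of a 1.1-fold higher number from compound 1 to compound 2 (0.06 log units; within the scatter) lies within the scatter. Compound 3 `O=C([C@@H]1C[C@@H]1F)N1CC2CC(C1)N2` gives 1.7 nM, the lowest of the three numbers, and its steps to the others, an 8.2-fold lower number from compound 1 to compound 3 (0.92 log units; beyond the scatter) and a 9.4-fold lower number from compound 2 to compound 3 (0.97 log units; beyond the scatter), both lie beyond the scatter, so it is the strongest inhibitor of the three.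

Compound 4 `C[C@@H]1C[C@@H]1C(=O)N1CC2CC(C1)N2` is not yet measured. It differs from compound 3 in one place: a group of 4 heavy atoms (4 carbon; one three-membered non-aromatic ring of carbon only) in place of a group of 4 heavy atoms (3 carbon, 1 fluorine; one three-membered non-aromatic ring of carbon only), on a carbonyl carbon. The three-membered ring is kept; the fluorine is gone and a fourth carbon takes its place on that ring.

Going by the values given here, the steps that bear on this are the two that led to compound 3: from compound 1 and from compound 2, both modest and beyond the scatter, and both brought in the fluorine together with the three-membered ring. Among the compounds with values here, no measured step separates what the ring contributes from what the fluorine contributes. Compound 4 is therefore expected to fall between the numbers of compound 3 and compound 1, with the step of a 3.5-fold higher number from compound 3 to compound 4 (0.55 log units; beyond the scatter) estimated in this assay . The estimate for compound 4 is 6 nM, ranging from 1.5 nM to 25 nM.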

Compound 4, inhibition constant: 22 nM
The estimate for compound 4 lay 3.7-fold (0.56 log units) below the measured number; the measured number falls inside the stated range.
By their numbers in this assay, from the lowest: compound 3; then compounds 1, 2 and 4 (each within the scatter of the next).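

In this assay, the three-membered ring stays while its fluorine gives way to carbon, and the result is a 13-fold higher number from compound 3 to compound 4 (1.11 log units; beyond the scatter), so the low number of compound 3 depends on the 2-fluorocyclopropyl group as a whole and not on the three-membered ring alone. Without the fluorine, the ring gives no measurable advantage at this carbonyl carbon: both a 1.6-fold higher number from compound 1 to compound 4 (0.20 log units; within the scatter) and a 1.4-fold higher number from compound 2 to compound 4 (0.14 log units; within the scatter) lie within the scatter, so an open chain, a four-membered ring and the all-carbon three-membered ring cannot be told apart here. Nothing available here accounts for the large effect of exchanging fluorine for carbon.

As far as these compounds go, it remains open whether fluorine would give a similar gain on a propyl chain or a cyclobutyl ring, or whether it needs the three-membered ring. Also unresolved is how a chlorine atom, a hydroxyl group or a second fluorine on the three-membered ring would compare, and whether the opposite stereochemistry of the 2-fluorocyclopropyl group would keep the low number of compound 3.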